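A few compounds are considered here, and "the series" means these few. Any claim that something is new, unique, unknown or untested is made for them only; others in the source may bear on it.

In a functional assay on DU-145 cells (Homo sapiens) for inhibition, read by MTT assay, with a stated time of 72 h (on this read-out lower numbers stand for stronger inhibition and higher numbers for weaker inhibition), compound 1 `Cc1ccc(N2CCN(C3=CC(=O)c4ccccc4C3=O)CC2)cc1` gives 8200 nM and compound 2 `O=C1C=C(N2CCN(c3cccc(Cl)c3)CC2)C(=O)c2ccccc21` gives 8300 nM so compound 2 stands level with compound 1, the two numbers lying within the scatter of each other. Compound 3 `COc1cccc(N2CCN(C3=CC(=O)c4ccccc4C3=O)CC2)c1` has not yet been measured. It carries methoxy in place of chloro on an aromatic carbon of compound 2, meta to a large group (methoxy in place of chloro on an aromatic carbon). For the measured compounds named here, only one measured step bears on this, the exchange of 4-methylphenyl for 3-chlorophenyl, a 1.0-fold higher number from compound 1 to compound 2 (0.01 log units; within the scatter) and it stays within the scatter. Going by the values given here, no measured compound carries methoxy, so this is thin evidence. No step beyond the scatter is expected in this assay in either direction. The expected step is a 1.0-fold lower number from compound 2 to compound 3 (0.02 log units; within the scatter) as an estimate. Compound 3 is estimated at 8000 nM (range 3500 nM to 18000 nM).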

Compound 3, half-maximal inhibitory concentration: 15000 nM
Estimate against measurement, compound 3: 1.9-fold (0.27 log units) below; measured number inside the range.
By their numbers in this assay, from the lowest: compounds 1, 2 and 3 (each within the scatter of the next).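

In this assay, the exchange of chloro for methoxy on an aromatic carbon, meta to a large group, gives a 1.8-fold higher number from compound 2 to compound 3 (0.26 log units; within the scatter) and the wider exchange of 4-methylphenyl for 3-methoxyphenyl gives a 1.8-fold higher number from compound 1 to compound 3 (0.26 log units; within the scatter) so compound 3 stands level with both compound 1 and compound 2. At this place on the ring, then, a group with one hydrogen-bond acceptor, where chloro has none, separates compound 3 from compound 2 by no more than the scatter. The compounds offer no measured property that could account for these numbers.

As far as these compounds go, whether an amine, a carboxylic acid or a longer chain such as ethoxy on this aromatic carbon would give a step beyond the scatter stays open. So does whether any exchange on the shared core would do so.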